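A few compounds are considered here, and "the series" means these few. Any claim that something is new, unique, unknown or untested is made for them only; others in the source may bear on it.

Working notes on the series. Three analogues of the shared core have been measured in a functional assay on HeLa cells (Homo sapiens) for cytotoxicity, read by MTT assay; on this read-out lower numbers stand for stronger inhibition and higher numbers for weaker inhibition. Compound 1 `CC(C)=CC[C@@H](OC[C@H](C)O)C1=CC(=O)c2c(O)ccc(O)c2C1=O` gives 40300 nM; compound 2 `CCCCC(O)CC(=O)O[C@H](CC=C(C)C)C1=CC(=O)c2c(O)ccc(O)c2C1=O` gives 72200 nM; compound 3 `CC[C@](C)(O)CC(=O)O[C@H](CC=C(C)C)C1=CC(=O)c2c(O)ccc(O)c2C1=O` gives 30200 nM. Compound 3 sits at the end of these three numbers with the smaller values: the step of a 1.3-fold lower number from compound 1 to compound 3 (0.13 log units; within the scatter) is within the scatter, while the step of a 2.4-fold lower number from compound 2 to compound 3 (0.38 log units; beyond the scatter) is beyond it, though modest.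

Compound 4 `CCCC(C)(O)CC(=O)O[C@H](CC=C(C)C)C1=CC(=O)c2c(O)ccc(O)c2C1=O` is not yet measured. Relative to compound 3 the change is 1-hydroxy-1-methylbutyl in place of 1-hydroxy-1-methylpropyl on a saturated chain carbon bound to a carbonyl carbon. Among the compounds with values here, the only step at this place, a 2.4-fold lower number from compound 2 to compound 3 (0.38 log units; beyond the scatter), was modest, and the other steps, a 1.8-fold higher number from compound 1 to compound 2 (0.25 log units; within the scatter) and a 1.3-fold lower number from compound 1 to compound 3 (0.13 log units; within the scatter), were within the scatter, so no change beyond the scatter is expected in this assay. Compound 4 is estimated at 35000 nM (range 15000 nM to 80000 nM), i.e. an expected step of a 1.2-fold higher number from compound 3 to compound 4 (0.06 log units; within the scatter).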

Compound 4, half-maximal inhibitory concentration: 72000 nM
Estimate against measurement, compound 4: 2.1-fold (0.31 log units) below; measured number inside the range.
By their numbers in this assay, from the lowest: compounds 3, 1, 4 and 2 (each within the scatter of the next, the first and the last beyond it).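

At this place, on a saturated chain carbon bound to a carbonyl carbon, 1-hydroxy-1-methylbutyl in place of 1-hydroxy-1-methylpropyl gives a 2.4-fold higher number from compound 3 to compound 4 (0.38 log units; beyond the scatter), so even this small extension of the chain is not silent. The other new steps, a 1.0-fold lower number from compound 2 to compound 4 (0.00 log units; within the scatter) and a 1.8-fold higher number from compound 1 to compound 4 (0.25 log units; within the scatter), both lie within the scatter. No measurement on hand accounts for the step from the propyl to the butyl group.

The compounds shown leave open whether a longer chain, such as 1-hydroxy-1-methylpentyl, follows the butyl group. They also leave open what an amine in place of the hydroxyl would do.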